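Working notes: 4-nitrophenyl in place of 3,4-dimethoxyphenyl

A few compounds are considered here, and "the series" means these few. Any claim that something is new, unique, unknown or untested is made for them only; others in the source may bear on it.

Measured in an ADME assay on HepG2 cells (Homo sapiens) for cytotoxicity, read by MTT assay, with a stated time of 7 days; on this read-out higher numbers stand for weaker inhibition and lower numbers for stronger inhibition:
compound 1 `COc1ccc(C2CC(c3ccc(O)cc3)=NN2C(=O)c2cccnc2)cc1OC`: 53600 nM
compound 2 `CCCc1ccc(C2CC(c3ccc(O)cc3)=NN2C(=O)c2cccnc2)cc1`: 41600 nM
compound 3 `CCc1ccccc1C1CC(c2ccc(O)cc2)=NN1C(=O)c1cccnc1`: 35400 nM

Compound 1 stands level with compound 2 and compound 3 once the scatter is allowed for. The open change leads to compound 4 `O=C(c1cccnc1)N1N=C(c2ccc(O)cc2)CC1c1ccc([N+](=O)[O-])cc1`: 4-nitrophenyl in place of 3,4-dimethoxyphenyl on a saturated ring carbon. Three measured swaps sit on the same saturated ring carbon: a 1.3-fold lower number from compound 1 to compound 2 (0.11 log units; within the scatter), a 1.5-fold lower number from compound 1 to compound 3 (0.18 log units; within the scatter) and a 1.2-fold lower number from compound 2 to compound 3 (0.07 log units; within the scatter). For the measured compounds named here, none of them brings in 4-nitrophenyl, so the group itself is untested and these steps are the only guide. No step beyond the scatter is therefore expected in this assay. The expected step is a 1.2-fold lower number from compound 1 to compound 4 (0.10 log units; within the scatter). Compound 4 is estimated at 43000 nM, with an expected range of 20000 nM to 90000 nM.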

Compound 4, half-maximal inhibitory concentration: 18600 nM
For compound 4 the middle estimate is 2.3-fold (0.36 log units) above the measured one; measured number below the stated range.
By their numbers in this assay, from the lowest: compounds 4, 3, 2 and 1 (each within the scatter of the next, the first and the last beyond it).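

In this assay, the saturated ring carbon now shows modest steps beyond the scatter, which no earlier swap there showed: a 2.9-fold lower number from compound 1 to compound 4 (0.46 log units; beyond the scatter) and a 2.2-fold lower number from compound 2 to compound 4 (0.35 log units; beyond the scatter). Against 2-ethylphenyl the new group stays level, with a 1.9-fold lower number from compound 3 to compound 4 (0.28 log units; within the scatter), so 4-nitrophenyl does not separate from every earlier group. Nothing available accounts for these steps.

On these data alone, whether the steps are specific to nitro remains open, and an amine or a nitrile on the same aromatic carbon would test this. A single nitro example also leaves open whether the trend extends to other groups.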